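Propoxy in place of dimethylamino on a benzimidazole series

A few compounds are considered here, and "the series" means these few. Any claim that something is new, unique, unknown or untested is made for them only; others in the source may bear on it.

Measured compounds:
compound 1, `FC(F)(F)c1ccc2[nH]c(-c3ccccc3)nc2c1`: 75.6%
compound 2, `COc1cc(-c2nc3cc([N+](=O)[O-])ccc3[nH]2)ccc1O`: 55.2%
compound 3, `CN(C)c1ccc(-c2nc3cc(C(F)(F)F)ccc3[nH]2)cc1`: 30.9%

In a functional assay on aorta (Rattus norvegicus, strain Wistar) for inhibition, with a stated time of 60 min (a higher number here means a larger maximal response, a lower number a smaller maximal response), compound 3 gives the lowest of the three numbers; compound 2 sits nearer to it, and compound 1 furthest from it, both beyond the scatter. Among the measured compounds shown here, the only step that touches compound 3 is a number 44.7 percentage points lower from compound 1 to compound 3 (beyond the scatter), a large fall when the group enters on an aromatic carbon.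

Compound 4, `CCCOc1ccc(-c2nc3cc(C(F)(F)F)ccc3[nH]2)cc1`, differs from compound 3 in one place: propoxy in place of dimethylamino on an aromatic carbon. For the measured compounds named here, no measured pair shows this change itself; the one step that bears on it is a number 44.7 percentage points lower from compound 1 to compound 3 (beyond the scatter), which shows that the group at this place sways the maximal response strongly. Propoxy has not been measured anywhere in the set, so its effect relative to dimethylamino is open.

Compound 4 is therefore expected to give a number between compound 3 and compound 1, and the step of a number 19.1 percentage points higher from compound 3 to compound 4 (beyond the scatter) is expected to be upward with wide uncertainty. The estimate for compound 4 in this assay is 50%, within 28% to 75%.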

Compound 4, largest response reached (Emax), in percent of the reference or control that the assay uses: 19%
For compound 4 the middle estimate is 31 percentage points above the measured one, and the stated range ends above it.
By their numbers in this assay, from the lowest: compound 4; then compound 3; then compound 2; then compound 1.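

In this assay, the fall seen with dimethylamino proves not to be confined to that group: propoxy in place of hydrogen on this aromatic carbon gives a number 56.6 percentage points lower from compound 1 to compound 4 (beyond the scatter), also a large step. Exchanging the two groups for each other gives a number 11.9 percentage points lower from compound 3 to compound 4 (beyond the scatter), a modest step, so in these three compounds replacing the hydrogen moves the number more than the choice between dimethylamino and propoxy does. No measurement shown here accounts for the lower number with propoxy.

The compounds shown leave open whether a shorter or longer alkoxy chain, such as methoxy or butoxy, would lower the number further or raise it again. They also leave open whether a primary amine or a carboxylic acid at this place would bring a similar fall.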